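The compounds below may be only part of what the source reports. "The series", "measured", "known", "first", "only" and "open" are said of these compounds alone.

In a physicochemical assay for lipophilicity, read by HPLC, at pH 7.4 (a higher number here means a more lipophilic compound, a lower number a more polar compound), compound 1 `CCC/N=C1\S/C(=C\c2ccc(O)cn2)C(=O)N1c1ccccc1C` gives 3 and compound 2 `CCC/N=C1\S/C(=C\c2ccc(O)c(Cl)c2)C(=O)N1C1CCOCC1` gives 3.7. Compound 3 `CCC/N=C1\S/C(=C\c2ccc(O)c(Cl)c2)C(=O)N1C(C)C` gives > 4.3, which is a limit of the assay and not a number. Compound 4 `CCC/N=C1\S/C(=C\c2ccc(O)c(Cl)c2)C(=O)N1C1CC1` carries cyclopropyl in place of isopropyl on an amide-type nitrogen in a ring. Among the measured compounds shown here, the one measured step at this place is a number at least 0.60 log units higher from compound 2 to compound 3 (beyond the scatter), with isopropyl in place of oxan-4-yl. That step is only a minimum and concerns a different exchange, so it carries over loosely. With isopropyl now leaving, a small step downward is expected in this assay, estimated as a number at least 0.20 log units lower from compound 3 to compound 4 (that floor lies within the scatter). Compound 4 is expected at 4.1, with an estimated range from 3.7 to 4.5.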

Compound 4, distribution coefficient: 3.4
The estimate for compound 4 lay 0.70 log units above the measured number, and the stated range ends above it.
By their numbers in this assay, from the lowest: compound 1; then compounds 4 and 2 (each within the scatter of the next). At a limit, above all of these: compound 3.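

In this assay, cyclopropyl in place of isopropyl on this amide-type nitrogen in a ring gives a number at least 0.90 log units lower from compound 3 to compound 4 (beyond the scatter), although the two groups have the same count of heavy atoms. Cyclopropyl in place of oxan-4-yl gives a number 0.30 log units lower from compound 2 to compound 4 (within the scatter), so these two groups are not told apart here. The first step is only a minimum, as compound 3 stands at a limit and not a number: the limit of > 4.3 in this assay, at which 1 of the 4 values shown sits.

Going by these compounds, it remains open how a longer chain or an amine at this place would read in this assay. On these data alone, whether the exchange of isopropyl for cyclopropyl gives a similar step on the core of compound 1 is also open.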